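A few compounds are considered here, and "the series" means these few. Any claim that something is new, unique, unknown or untested is made for them only; others in the source may bear on it.

Measured so far:
- compound 1, `CS(=O)(=O)c1cc(Cl)ccc1NCC1=NCCN1`, giving 513 nM
- compound 2, `CSc1ccc(F)cc1NCC1=NCCN1`, giving 2.29 nM
- compound 3, `CS(=O)(=O)c1ccc(Cl)cc1NCC1=NCCN1`, giving 2.82 nM

In a functional assay for agonist activity at Alpha-1A adrenergic receptor (Homo sapiens) (on this read-out lower numbers stand for an effect already at smaller amounts and higher numbers for an effect only at larger amounts of compound), compound 3 stands next to compound 2, the two numbers within the usual scatter of each other, while compound 1 lies far away with a much higher number, well beyond the scatter. Compound 4, `CS(=O)(=O)c1ccc(F)cc1NCC1=NCCN1`, has not yet been measured. It differs from compound 3 in one place: fluoro in place of chloro on an aromatic carbon. Nothing else changes, so the shared core with its methylsulfonyl group stays as in compound 3. Among the compounds with values here, no comparable single step between measured compounds is known here. Since compound 2 carries fluoro and gives 2.29 nM, a step of about a 1.1-fold higher number from compound 3 to compound 4 (0.03 log units; within the scatter) is expected, that is, none beyond the scatter. Compound 4 is estimated at 3 nM, between 1 nM and 10 nM.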

Compound 4, half-maximal effective concentration: 16.6 nM
For compound 4 the middle estimate is 5.5-fold (0.74 log units) below the measured one, and the stated range ends below it.
By their numbers in this assay, from the lowest: compounds 2 and 3 (each within the scatter of the next); then compound 4; then compound 1.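

In this assay the halogen para to the methylsulfonyl group is not interchangeable: fluoro in place of chloro alone gives a 5.9-fold higher number from compound 3 to compound 4 (0.77 log units; beyond the scatter) on this core. With fluoro kept, the other group counts too, as methylsulfonyl in place of methylsulfanyl gives a 7.2-fold higher number from compound 2 to compound 4 (0.86 log units; beyond the scatter) in the same direction, so the low number of compound 2 does not carry over to compound 4. Nothing measured here explains either step.
Open, going by these compounds, is where bromo or methyl at this position would fall relative to chloro and fluoro. Also open, on these data alone, is whether chloro would pair with methylsulfanyl as well as fluoro does.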